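The source may report more compounds than this note shows. Statements on the series, on what has been measured and on what is new or still open speak of the compounds shown alone.

Compound 1 `O/N=C(\CCN1CCN(c2ccccn2)CC1)c1ccccc1Cl` gives 74% in a functional assay on HEK293 cells with D(4) dopamine receptor (Homo sapiens) as the target, read by FLIPR (a lower number here means a smaller maximal response, a higher number a larger maximal response), and compound 2 `Cc1cccc(/C(CCN2CCN(c3ccccn3)CC2)=N/O)c1` gives 74% in this assay; the step of no change at the digits printed from compound 1 to compound 2 (within the scatter) leaves compound 1 level with compound 2 on this assay. Compound 3 `O/N=C(\CCN1CCN(c2ccccn2)CC1)c1cc(F)cc(F)c1` differs from compound 1 by 3,5-difluorophenyl in place of 2-chlorophenyl on a carbon with a double bond to nitrogen. Within the data shown here, the only step that bears on this is the aryl exchange at the same carbon, which was no change at the digits printed from compound 1 to compound 2 (within the scatter); on that basis no step beyond the scatter is expected in this assay, that is a number 1 percentage points lower from compound 1 to compound 3 (within the scatter). Compound 3 is therefore expected at 73%, with a range of 57% to 89%.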

Compound 3, largest response reached (reported as efficacy), in percent of the reference or control that the assay uses: 74%
Estimate against measurement, compound 3: 1 percentage points below, and the stated range covers the measured number.
By their numbers in this assay, from the lowest: compounds 1, 2 and 3 (each within the scatter of the next).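

At the carbon with a double bond to nitrogen, 3,5-difluorophenyl in place of 2-chlorophenyl gives no change at the digits printed from compound 1 to compound 3 (within the scatter) in this assay, and 3,5-difluorophenyl in place of 3-methylphenyl gives no change at the digits printed from compound 2 to compound 3 (within the scatter). The level read-out at this carbon therefore extends to a third aryl group, one carrying two fluorine atoms, and none of the three compounds goes against it. Nothing at hand gives a reason for this level read-out.

Still open, from the compounds shown here alone, is whether the response in this assay holds with a cyclohexyl group at this carbon or with a carboxylic acid on the phenyl ring.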